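Trifluoromethyl Added to a Shared Core Under Cytotoxicity Testing

This account rests on a few compounds, and the source may have more. Where it says the series, first, only, none or still open, it means among the compounds named here.

Of the compounds shown here, three of one series have been tested in a functional assay on Huh7.5.1 cells (Homo sapiens) for cytotoxicity, read by MTT assay, with a stated time of 72 h; a lower number here means that less compound is tolerated, a higher number that more compound is tolerated. Compound 1 `C=c1[nH]c(=O)/c(=C/c2ccc(OC)c(OC)c2)[nH]c1=O` reached only the limit of > 20000 nM. Compound 2 `C=CC(C)(C)c1[nH]c2ccccc2c1/C=c1\[nH]c(=O)c(=C)[nH]c1=O` likewise stopped at the limit of > 20000 nM. Compound 3 `C=c1[nH]c(=O)/c(=C/c2ccccc2)[nH]c1=O`, the parent of the step followed here, also returned only the limit of > 20000 nM. Compound 3 thus stands together with compounds 1 and 2 at a position defined by the limit of > 20000 nM in this assay, at which 3 of the 3 values shown sit, and no measured number separates any of the three.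

Compound 4 `C=c1[nH]c(=O)/c(=C/c2ccc(C(F)(F)F)cc2)[nH]c1=O` differs from compound 3 by trifluoromethyl in place of hydrogen on an aromatic carbon. Among the measured compounds shown here, since every measured compound sits at the same limit, no step between measured compounds is available to guide the size of this change. Compound 4 is therefore expected to move from compound 3 by a step that the limit leaves unreadable from compound 3 to compound 4 in this assay, which is to say no step beyond the scatter, and most probably again only a limit. The estimate for compound 4 in this assay is 25000 nM, within a range from 10000 nM to 60000 nM, with the expectation that the reported result is once more a limit rather than a number.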

Compound 4, half-maximal cytotoxic concentration: > 20000 nM
Compound 4 gave a limit, no number (the forecaster's own chance of this, stated with the estimate: 85%); the middle value does not contradict the limit.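

Compound 3 and compound 4 both returned only a limit in this assay, so no step can be read between them. All the compounds shown now stand at one position: the limit of > 20000 nM in this assay, at which 4 of the 4 values shown sit.

The compounds shown leave open whether trifluoromethyl in place of hydrogen on an aromatic carbon changes cytotoxicity at all, and how the four compounds rank.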